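Swapping a pentyl chain for allyl on the oxygen

A few compounds are considered here, and "the series" means these few. Any claim that something is new, unique, unknown or untested is made for them only; others in the source may bear on it.

Compound 1 `CCOC(=O)c1cnc(-c2ccccc2[N+](=O)[O-])[nH]c1=O`: "not determined" (no result reported)
Compound 2 `CCOC(=O)c1cnc(-c2ccccc2OC(C)C)[nH]c1=O`: 2 mg/kg
Compound 3 `CCCCCOc1ccccc1-c1ncc(C(=O)OCC)c(=O)[nH]1`: 2 mg/kg

All three compounds share one core and went through a functional assay on the whole organism (strain Sprague-Dawley) for inhibition, with Rattus norvegicus as the target, with a stated time of 10 min; a higher number here means that more compound is needed for the effect, a lower number that less compound is needed. Among the compounds with values here, there, compound 3 gives 2 mg/kg and stands level with compound 2 , the only other compound with a number. Compound 1 offers no comparison.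

The next compound to be measured is compound 4 `C=CCOc1ccccc1-c1ncc(C(=O)OCC)c(=O)[nH]1`. Its difference from compound 3 is vinyl in place of butyl on a saturated chain carbon bound to an oxygen on an aromatic ring. Put more simply, a pentyl chain gives way to an allyl chain, which brings in a double bond.

Within the data shown here, only one measured step bears on this change: no change at the digits printed from compound 2 to compound 3 (within the scatter). That swap also concerned the chain on this oxygen, and it stayed within the scatter. Among the measured compounds shown here, it is a single step, and no measured compound yet carries a double bond in that chain, so the evidence is thin. No step beyond the scatter in either direction is therefore expected in this assay.

The estimated step is no change at the digits printed from compound 3 to compound 4 (within the scatter).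

For compound 4 the expected value is 2 mg/kg, with an estimated range from 0.7 mg/kg to 6 mg/kg.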

Compound 4, dose for 50% inhibition: 0.5 mg/kg
For compound 4 the middle estimate is 4.0-fold (0.60 log units) above the measured one, and the stated range ends above it.
By their numbers in this assay, from the lowest: compound 4; then compounds 2 and 3 (each within the scatter of the next).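

In this assay, the group on this oxygen turns out to matter: the earlier swap gave no change at the digits printed from compound 2 to compound 3 (within the scatter), whereas the allyl chain gives a 4.0-fold lower number from compound 3 to compound 4 (0.60 log units; beyond the scatter). The same chain also gives a 4.0-fold lower number from compound 2 to compound 4 (0.60 log units; beyond the scatter), so among the three compounds with a number, compound 4 stands apart from the two whose chains carry no double bond. Nothing measured here explains this shift.

The change from pentyl to allyl both shortens the chain and brings in a double bond, so the compounds shown cannot tell which of the two goes with the lower number; a plain propyl chain on the same oxygen would separate them. Also open, on these data alone, is how a benzyl group or a chain ending in an amine would behave at this position.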